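From ethylamino to dimethylamino: compound 3 to compound 4

The source may report more compounds than this note shows. Statements on the series, on what has been measured and on what is new or still open speak of the compounds shown alone.

Among the measured compounds shown here, compound 3 `CCNCC(=O)Nc1cc(OC)ccc1C(=O)c1ccc(OC)c2c1OC(C)(C)C=C2` gives 2690 nM in a functional assay on HeLa cells (Homo sapiens) for antiproliferative activity, read by MTT assay, with a stated time of 48 h (on this read-out higher numbers stand for weaker inhibition and lower numbers for stronger inhibition), and holds the highest of the three numbers so far, although compound 1 `COc1ccc(C(=O)c2ccc(OC)c3c2OC(C)(C)C=C3)c(NC(=O)CBr)c1` at 2140 nM lies within the scatter of it. Compound 2 `CNCC(=O)Nc1cc(OC)ccc1C(=O)c1ccc(OC)c2c1OC(C)(C)C=C2` gives 870 nM and holds the lowest number.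

Compound 4 `COc1ccc(C(=O)c2ccc(OC)c3c2OC(C)(C)C=C3)c(NC(=O)CN(C)C)c1` differs from compound 3 in one group, with dimethylamino in place of ethylamino on a saturated chain carbon bound to a carbonyl carbon. For the measured compounds named here, no measured compound carries dimethylamino, so the evidence is indirect.

The nearest evidence is the pair of methylamino and ethylamino groups, where the series shows a 3.1-fold higher number from compound 2 to compound 3 (0.49 log units; beyond the scatter) and so responds to a small change in this group. The steps away from bromo frame the same span, with a 2.5-fold lower number from compound 1 to compound 2 (0.39 log units; beyond the scatter) for methylamino and a 1.3-fold higher number from compound 1 to compound 3 (0.10 log units; within the scatter) for ethylamino. Dimethylamino is expected to fall inside that span, without matching either group.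

The expected outcome in this assay is a 1.8-fold lower number from compound 3 to compound 4 (0.25 log units; within the scatter) and so no step beyond the scatter is expected, with any drift expected toward a lower number. Compound 4 is estimated at 1500 nM with an expected range of 600 nM to 3800 nM on this estimate.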

Compound 4, half-maximal inhibitory concentration: 1050 nM
Compound 4: middle estimate off by 1.4-fold (0.15 log units), on the high side, and the stated range covers the measured number.
By their numbers in this assay, from the lowest: compounds 2 and 4 (each within the scatter of the next); then compounds 1 and 3 (each within the scatter of the next).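

In this assay, the two groups have the same atoms joined differently, yet the change to dimethylamino gives a 2.6-fold lower number from compound 3 to compound 4 (0.41 log units; beyond the scatter), so this place on the saturated chain carbon bound to a carbonyl carbon responds to how the amine is substituted and not only to its atom count. The site of an added methyl also matters: on the amine nitrogen it gives a 1.2-fold higher number from compound 2 to compound 4 (0.08 log units; within the scatter), while on the saturated chain carbon bound to an amine nitrogen it gives a 3.1-fold higher number from compound 2 to compound 3 (0.49 log units; beyond the scatter), and the amine hydrogen of compound 2 is therefore not needed to hold the number at this level. Set against bromo, dimethylamino gives a 2.0-fold lower number from compound 1 to compound 4 (0.31 log units; beyond the scatter), which places it with methylamino, whereas ethylamino gives a 1.3-fold higher number from compound 1 to compound 3 (0.10 log units; within the scatter), so the replacement of bromo does not move the number beyond the scatter for every amine.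

No measurement at hand bears on what lies behind these differences. Still open, going by these compounds, is whether diethylamino, or a ring amine such as pyrrolidine or morpholine, stays in the range of compound 2 and compound 4 or moves toward compound 3.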